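A few compounds are considered here, and "the series" means these few. Any claim that something is new, unique, unknown or untested is made for them only; others in the source may bear on it.

In a functional assay on Hep 3B2 cells (Homo sapiens) for antiproliferative activity, with a stated time of 72 h (a higher number here means a weaker inhibitor, a lower number a stronger inhibitor), compound 1 (`C=CC(=O)N1CCN(CCn2cc(-c3ccc(OC)c(OC)c3)c3cnc(NC)nc32)CC1`) reaches no number, only a limit (> 10000 nM). Compound 3 (`C=CC(=O)N1CCN(CCn2cc(-c3cc(OC)cc(OC)c3)c3cnc(NC)nc32)CC1`) has 3,5-dimethoxyphenyl in place of 3,4-dimethoxyphenyl on an aromatic carbon of the shared core, and 3,5-dimethoxyphenyl in place of 3,4-dimethoxyphenyl on an aromatic carbon counts that change. Among the measured compounds shown here, no measured pair shows this change. Compound 2 (`C=CC(=O)NC1CCCCC1Nc1ccc2c(C(=O)c3cc(OC)cc(OC)c3)c[nH]c2n1`) has a different core but also carries 3,5-dimethoxyphenyl, and it gives a measured value (258 nM). That single value is the only support for expecting a stronger result, so the expected step is an at least 6.6-fold lower number from compound 1 to compound 3 (0.82 log units; beyond the scatter) and remains uncertain. Compound 3 is estimated at 1500 nM in this assay, with an expected range from 150 nM to 10000 nM as the outer bounds.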

Compound 3, half-maximal inhibitory concentration: > 10000 nM
Compound 3: no number, only a limit (the forecaster's own chance of this, stated with the estimate: 30%); at least 6.6-fold (0.82 log units) between middle value and limit.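

No step can be read between compound 1 and compound 3, since both stop at a limit in this assay: the limit of > 10000 nM in this assay, at which 2 of the 3 values shown sit.

The compounds shown leave open whether 3,5-dimethoxyphenyl in place of 3,4-dimethoxyphenyl on the shared core changes the antiproliferative activity at all.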